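A few compounds are considered here, and "the series" means these few. Any claim that something is new, unique, unknown or untested is made for them only; others in the source may bear on it.

The study examines three measured compounds that share a core: compound 1 `CC(C)Nc1nc(NCc2ccco2)c2cccc(Cl)c2n1`, compound 2 `CC(C)Nc1nc(NCc2ccco2)c2cc(Cl)ccc2n1` and compound 3 `Cc1cccc2c(NCc3ccco3)nc(NC(C)C)nc12`. In an ADME assay on J774.A1 cells (Mus musculus) for cytotoxicity, read by MTT assay, with a stated time of 72 h (on this read-out lower numbers stand for an effect already at smaller amounts and higher numbers for an effect only at larger amounts of compound), compound 1 gives a value that is a limit of the assay, > 33000 nM. In this assay compound 2 likewise reaches only a limit, > 33000 nM. In this assay compound 3 also stops at a limit, > 33000 nM. The change from compound 1 to compound 3, (methyl in place of chloro on an aromatic carbon), makes a step that the two limits leave unreadable from compound 1 to compound 3, which stays unreadable because of the limit of > 33000 nM in this assay, at which 3 of the 3 values shown sit. The difference between the cores of compound 1 and compound 2 is not broken down here. Compound 4 `Cc1ccc2nc(NC(C)C)nc(NCc3ccco3)c2c1` is not yet measured; it arises from compound 2 by the same kind of change, (methyl in place of chloro on an aromatic carbon), though here the place is meta to a fused ring and para to a fused ring rather than ortho to a fused ring and meta to a fused ring. For compound 4 the expected step is a step that the limit leaves unreadable from compound 2 to compound 4, resting on the step that the two limits leave unreadable from compound 1 to compound 3 and on (the limit of > 33000 nM in this assay, at which 3 of the 3 values shown sit). Compound 4 is therefore estimated at 40000 nM, expected within 20000 nM to 100000 nM.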

Compound 4, half-maximal effective concentration: > 33000 nM
Compound 4: a limit, no number (the forecaster's own chance of this, stated with the estimate: 85%); the middle value lies beyond the limit too.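

Compound 2 and compound 4 both stop at a limit in this assay, so no new step can be read between them: the limit of > 33000 nM in this assay, at which 4 of the 4 values shown sit.

The compounds shown leave open whether methyl in place of chloro on an aromatic carbon changes anything in this assay, and at what amount any of the four compounds would show an effect.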